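The source may hold more compounds than are shown below. What is called first, only, known or untested is meant among the compounds shown, and "the series" means these compounds.

Measured compounds in an assay on isolated protein for inhibition of DNA topoisomerase 1 (Homo sapiens), with a stated time of 30 min, tested at 100 uM; a lower number here means a weaker effect, a higher number a stronger effect of the compound at the concentration tested:
- compound 1, `Oc1cccc(-c2cc(-c3ccsc3)cc(-c3ccccc3O)n2)c1`: compound 1 gives 10.2%
- compound 2, `Oc1ccc(-c2cc(-c3ccsc3)cc(-c3ccccc3O)n2)cc1`: compound 2 gives 13.8%
- compound 3, `Oc1ccc(-c2cc(-c3ccsc3)cc(-c3ccc(O)cc3)n2)cc1`: compound 3 gives 61.7%

Compound 2 and compound 1 lie within the scatter of each other, the difference being a number 3.6 percentage points higher from compound 1 to compound 2 (within the scatter). Compound 3 stands clearly apart from both, with a number 47.9 percentage points higher from compound 2 to compound 3 (beyond the scatter) separating it from compound 2. Both measured steps change a hydroxyphenyl group on the shared core; neither touches the five-membered ring.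

Compound 4, `Oc1ccc(-c2cc(-c3ccoc3)cc(-c3ccccc3O)n2)cc1`, is the next case to read. It differs from compound 2 only as furan-3-yl in place of thiophen-3-yl on an aromatic carbon, on an aromatic carbon of a six-membered aromatic ring with 1 nitrogen, opposite the ring nitrogen. For the measured compounds named here, no measured step bears on this exchange: the pair of hydroxyphenyl swaps says nothing about a furan-3-yl in place of thiophen-3-yl, and the two groups match in count of heavy atoms, donors and acceptors. The working expectation is therefore no step beyond the scatter in this assay, with the estimate resting on compound 2 alone.

Compound 4 is expected at 14%, in the range 3% to 30%. The expected step of a number 0.2 percentage points higher from compound 2 to compound 4 (within the scatter) is thus taken as within the scatter.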

Compound 4, a percentage reported as inhibition, at one concentration (the size of the read-out at that concentration, not a potency): 30.1%
For compound 4 the middle estimate is 16.1 percentage points below the measured one, outside the stated range (above it).
By their numbers in this assay, from the lowest: compounds 1 and 2 (each within the scatter of the next); then compound 4; then compound 3.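

In this assay the exchange of thiophen-3-yl for furan-3-yl gives a number 16.3 percentage points higher from compound 2 to compound 4 (beyond the scatter) even though the two groups match in heavy atoms, donors and acceptors, and differ only in sulfur against oxygen in the five-membered ring. For the compounds shown here, the earlier steps changed only a hydroxyphenyl group, so this is the first sign that the position opposite the ring nitrogen also moves the read-out, with the 2-hydroxyphenyl and 4-hydroxyphenyl groups held fixed. Nothing at hand accounts for the size or direction of this step.

Still open, going by these compounds, is whether furan-3-yl in place of thiophen-3-yl moves the read-out in the same direction and by a similar amount when the two hydroxyphenyl groups are those of compound 3, which gives 61.7% with thiophen-3-yl in this position. Also open, on these data alone, is how this position responds to groups of a different kind, such as a plain phenyl ring, an aminomethyl group or a carboxylic acid, and whether any such difference persists beyond the single tested concentration.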